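Swapping an Aryl Amine for a Benzyl Amine

The source may report more compounds than this note shows. Statements on the series, on what has been measured and on what is new or still open speak of the compounds shown alone.

Compound 1 `Cc1ccc(NC2=CC(=O)c3c(nc4n3[C@H]3OC[C@@H](O)[C@H]3OC4)C2=O)cc1C` is measured in a functional assay on MGC-803 cells (Homo sapiens) for inhibition, read by sulforhodamine B assay (on this read-out lower numbers stand for stronger inhibition and higher numbers for weaker inhibition), where compound 1 gives 1050 nM, the lowest of the two numbers reported. Its nearest neighbour is compound 2 `COc1ccc(NC2=CC(=O)c3nc4n(c3C2=O)[C@H]2OC[C@@H](O)[C@H]2OC4)cc1`, for which compound 2 gives 1680 nM; the gap to compound 1 lies within the scatter. Compound 3 `CCCN(CCC)C1=CC(=O)c2nc3n(c2C1=O)[C@H]1OC[C@@H](O)[C@H]1OC3` returns only a limit of the assay, compound 3 being reported at > 16000 nM. Among the measured compounds shown here, the one measured step, an at least 9.5-fold higher number from compound 2 to compound 3 (0.97 log units; beyond the scatter), is therefore a loss of at least modest size, and the only evidence about it is the limit of > 16000 nM in this assay, at which 1 of the 3 values shown sits.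

The unmeasured compound 4 `O=C1C(NCc2ccccc2)=CC(=O)c2c1nc1n2[C@H]2OC[C@@H](O)[C@H]2OC1` differs from compound 1 by benzyl in place of 3,4-dimethylphenyl on an amine nitrogen. This change bears a resemblance to the measured step, since in both an arylamine gives way to an amine carrying a saturated carbon, although compound 4 keeps an aromatic ring one carbon further out. A weakening beyond the scatter is therefore expected, though probably less severe than the step from compound 2 to compound 3. Compound 4 is accordingly expected to show a change of a 4.8-fold higher number from compound 1 to compound 4 (0.68 log units; beyond the scatter). The estimate for compound 4 is 5000 nM, with a range from 1500 nM to 16000 nM.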

Compound 4, half-maximal inhibitory concentration: 3490 nM
Compound 4: middle estimate off by 1.4-fold (0.16 log units), on the high side; the range from low to high includes it.
By their numbers in this assay, from the lowest: compounds 1 and 2 (each within the scatter of the next); then compound 4. At a limit, above all of these: compound 3.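

In this assay, the change on the amine nitrogen gives a 3.3-fold higher number from compound 1 to compound 4 (0.52 log units; beyond the scatter), the first step measured from compound 1. It shows that this nitrogen can carry benzyl, whose ring is attached through a saturated carbon, and still return a measured number, although 3,4-dimethylphenyl gives the lower number of the two. Compound 3, with dipropylamino, remains only a limit, so how far its number lies from that of compound 4 cannot be read: the limit of > 16000 nM in this assay, at which 1 of the 4 values shown sits.

On these data alone, whether methyl groups on the benzyl ring would bring the number back towards that of compound 1 remains open. So does the effect of a phenethyl chain or a cyclohexyl group on the same nitrogen, which would show whether an aromatic ring is needed there at all.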